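Compound 4 and the thiomorpholin-4-yl exchange

The compounds below may be only part of what the source reports. "The series", "measured", "known", "first", "only" and "open" are said of these compounds alone.

In an ADME assay for metabolic stability, with a stated time of 1 h, at pH 1.2 (on this read-out higher numbers stand for a more stable compound and lower numbers for a less stable compound), compound 3 `CC(=O)NC[C@H]1CN(c2ccc(-c3ccc(/C=N/N4CCN(C)CC4)c(O)c3)c(F)c2)C(=O)O1` stands lowest of the three measured compounds at 35%, while compound 1 `CC(=O)NC[C@H]1CN(c2ccc(-c3ccc(/C=N/N4CCN(C)CC4)nc3)c(F)c2)C(=O)O1` gives 96.8% and compound 2 `CC(=O)NC[C@H]1CN(c2ccc(-c3ccc(/C=N/N4CCSCC4)nc3)c(F)c2)C(=O)O1` gives 99%. Compound 4 `CC(=O)NC[C@H]1CN(c2ccc(-c3ccc(/C=N/N4CCSCC4)c(O)c3)c(F)c2)C(=O)O1` carries thiomorpholin-4-yl in place of 4-methylpiperazin-1-yl on a double-bonded nitrogen, the difference from compound 3 being (thiomorpholin-4-yl in place of 4-methylpiperazin-1-yl on a double-bonded nitrogen). The same exchange has been measured once. With only a number 2.2 percentage points higher from compound 1 to compound 2 (within the scatter) to go on, no step beyond the scatter is expected in this assay. That step lies near the top of the scale, far from compound 3, so the range stays wide. Compound 4 is estimated at 38%, with an expected range of 22% to 55%. The expected step is a number 3 percentage points higher from compound 3 to compound 4 (within the scatter).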

Compound 4, percent of the compound remaining: 94.6%
The estimate for compound 4 lay 56.6 percentage points below the measured number; measured number outside the range, above it.
By their numbers in this assay, from the lowest: compound 3; then compounds 4, 1 and 2 (each within the scatter of the next).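

In this assay, the exchange at this position is not silent on every core: it brings a number 59.6 percentage points higher from compound 3 to compound 4 (beyond the scatter). The low number therefore does not follow from the hydroxyl-bearing core alone, since it appears there only with 4-methylpiperazin-1-yl and not with thiomorpholin-4-yl. The size of the exchange depends on the core that carries it: the same change on two cores in this assay, a number 2.2 percentage points higher (within the scatter) from compound 1 to compound 2 and a number 59.6 percentage points higher (beyond the scatter) from compound 3 to compound 4, 57.4 percentage points apart, beyond the scatter of two such steps

On these data alone, it remains open whether morpholin-4-yl or piperidin-1-yl on the same double-bonded nitrogen would follow thiomorpholin-4-yl on this core. What lies behind the dependence on the core also remains open.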